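This account rests on a few compounds, and the source may have more. Where it says the series, first, only, none or still open, it means among the compounds named here.

Measured compounds in an ADME assay on CRL8155 cells (Homo sapiens) for cytotoxicity, read by resazurin assay, with a stated time of 72 h; on this read-out lower numbers stand for an effect already at smaller amounts and higher numbers for an effect only at larger amounts of compound:

compound 1, `CN1CCC(Cn2c(N)nc3ccc(C(=O)c4ccccc4)cc32)CC1` – > 30000 nM
compound 2, `Nc1nc2ccc(C(=O)c3ccccc3)cc2n1C[C@@H]1CCCN1` – > 30000 nM

In this assay compound 1 gives only a limit, > 30000 nM. In this assay compound 2 likewise gives only a limit, > 30000 nM. Among the compounds with values here, both values shown therefore sit at the same place, (the limit of > 30000 nM in this assay, at which 2 of the 2 values shown sit), and the single step between measured compounds, a step that the two limits leave unreadable from compound 1 to compound 2, cannot be sized. Compound 2 thus stands at the top of what the assay can report; no value in the series lies below it.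

Compound 3, `CN1CCC[C@H]1CCn1c(N)nc2ccc(C(=O)c3ccccc3)cc21`, is still to be measured in this assay. It differs from compound 2 as follows: (1-methylpyrrolidin-2-yl)methyl in place of pyrrolidin-2-yl on a saturated chain carbon bound to an aromatic nitrogen. Within the data shown here, the only measured step touching the same place, a step that the two limits leave unreadable from compound 1 to compound 2, is unreadable, so no measured step gives a direction or size for this change. With both neighbours at the limit, compound 3 is expected to stay there as well, so that the step that the limit leaves unreadable from compound 2 to compound 3 is expected to be none beyond the scatter. Compound 3 is estimated at 40000 nM, with a range of 15000 nM to 120000 nM.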

Compound 3, half-maximal effective concentration: > 30000 nM
Compound 3 ended at the assay's limit (the forecaster's own chance of this, stated with the estimate: 80%); the middle value does not contradict the limit.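

In this assay compound 3 gives > 30000 nM as a limit of the assay. The steps among compound 1, compound 2 and compound 3 cannot be read, so no new step results, and all three share one place: the limit of > 30000 nM in this assay, at which 3 of the 3 values shown sit.
The compounds shown leave open whether any group on the saturated chain carbon bound to an aromatic nitrogen gives a measurable value.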